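The source may report more compounds than this note shows. Statements on the series, on what has been measured and on what is new or still open speak of the compounds shown alone.

In a functional assay on J774 cells (Mus musculus) for cytotoxicity (a higher number here means a weaker inhibitor, a lower number a stronger inhibitor), compound 1 `CCCN(CCC)c1c([N+](=O)[O-])cc(S(=O)(=O)Nc2ccc(C)cc2)cc1[N+](=O)[O-]` gives 11000 nM, and compound 2 `CCCN(CCC)c1c([N+](=O)[O-])cc(S(=O)(=O)Nc2cccc(Cl)c2)cc1[N+](=O)[O-]` gives 8700 nM, so compound 2 stands within the scatter of compound 1. Compound 3 `CCCN(CCC)c1c([N+](=O)[O-])cc(S(=O)(=O)Nc2cc(Cl)cc(Cl)c2)cc1[N+](=O)[O-]` differs from compound 2 by chloro in place of hydrogen on an aromatic carbon, turning 3-chlorophenyl into 3,5-dichlorophenyl. Within the data shown here, the only measured step bearing on this group is a 1.3-fold lower number from compound 1 to compound 2 (0.10 log units; within the scatter), and it swaps a different substituent. On that evidence, no step beyond the scatter is expected in this assay. The estimated step is a 1.5-fold lower number from compound 2 to compound 3 (0.16 log units; within the scatter). For compound 3 the expected value is 6000 nM, with an estimated range of 2500 nM to 13000 nM.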

Compound 3, half-maximal inhibitory concentration: 5100 nM
Compound 3: middle estimate off by 1.2-fold (0.07 log units), on the high side; low and high end bracket the measured number.
By their numbers in this assay, from the lowest: compounds 3, 2 and 1 (each within the scatter of the next, the first and the last beyond it).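

In this assay the added chloro that turns 3-chlorophenyl into 3,5-dichlorophenyl gives a 1.7-fold lower number from compound 2 to compound 3 (0.23 log units; within the scatter), so this place on the ring takes a second chloro with no step beyond the scatter. Among these compounds, replacing 4-methylphenyl with 3,5-dichlorophenyl on the sulfonamide nitrogen gives a 2.2-fold lower number from compound 1 to compound 3 (0.33 log units; beyond the scatter), the first step beyond the scatter. Nothing shown accounts for either step.

Open, on these data alone, is how an amine or a carboxylic acid at this place on the ring would read in this assay. Also open, as far as these compounds go, is whether a longer chain on the core's other nitrogen would shift the number.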